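Bromo for Fluoro on the Shared Core

The source may report more compounds than this note shows. Statements on the series, on what has been measured and on what is new or still open speak of the compounds shown alone.

In a functional assay on HeLa cells (Homo sapiens) for antiproliferative activity, read by MTT assay, with a stated time of 48 h (a higher number here means a weaker inhibitor, a lower number a stronger inhibitor), compound 2 `Fc1ccc(-c2nn(-c3ccccc3)cc2-c2nc3cc(F)ccc3[nH]2)cc1` gives 1570 nM and compound 1 `Brc1ccc2[nH]c(-c3cn(-c4ccccc4)nc3-c3ccccc3)nc2c1` gives 1760 nM, two values within the scatter of each other. Compound 3 `Fc1ccc(-c2nn(-c3ccccc3)cc2-c2nc3cc(Br)ccc3[nH]2)cc1` has bromo in place of fluoro on an aromatic carbon of compound 2: bromo in place of fluoro on an aromatic carbon. Among the measured compounds shown here, no measured pair shows this change on its own. Compound 1, which also carries bromo, reads 1760 nM, so no step beyond the scatter is expected in this assay. The expected change is a 1.0-fold higher number from compound 2 to compound 3 (0.01 log units; within the scatter). Compound 3 is expected at 1600 nM, with an estimated range of 750 nM to 3400 nM.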

Compound 3, half-maximal inhibitory concentration: 4940 nM
Compound 3: middle estimate off by 3.1-fold (0.49 log units), on the low side; measured number outside the range, above it.
By their numbers in this assay, from the lowest: compounds 2 and 1 (each within the scatter of the next); then compound 3.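

In this assay, the position on the six-membered ring of the fused system proves sensitive to which halogen it carries: bromo in place of fluoro gives a 3.1-fold higher number from compound 2 to compound 3 (0.50 log units; beyond the scatter). With bromo held there, fluoro in place of hydrogen on an aromatic carbon elsewhere also gives a weaker number, a 2.8-fold higher number from compound 1 to compound 3 (0.45 log units; beyond the scatter). Nothing available explains either step.

On these data alone, whether chloro or methoxy at this position would read nearer to fluoro or to bromo remains open. So does how an amine there would read.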